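Cytotoxicity notes: methoxy on the cyclohexyl side chain

The compounds below may be only part of what the source reports. "The series", "measured", "known", "first", "only" and "open" are said of these compounds alone.

Three compounds of the series carry cytotoxicity data, all of them against the same cell line. Compound 1 `O=C1NC2=C(C(=O)OC2)C(c2cccc(O)c2)N1` and compound 2 `O=C1NC2=C(C(=O)OCC2)C(c2cccc(O)c2)N1` share a smaller bicyclic core; compound 3 `CCC1=C(C(=O)CCC2CCCCC2)[C@H](c2ccc(O)c(Cl)c2)NC(=O)N1` carries an ethyl group and a ketone-linked side chain on its core. In an ADME assay on cells (Homo sapiens) for cytotoxicity (on this read-out higher numbers stand for lower toxicity in this test and lower numbers for higher toxicity in this test), compound 1 returns only a limit, > 10000 nM. Compound 2 also returns only a limit in this assay, > 10000 nM. Compound 3 gives a limit as well in this assay, > 10000 nM. Where compound 3 stands is therefore the ceiling of the test rather than a number; the whole set sits at the limit of > 10000 nM in this assay, at which 3 of the 3 values shown sit. For the measured compounds named here, no pair among the measured compounds differs in a single place, so no measured step is available to size the effect of any change.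

Compound 4 `CCC1=C(C(=O)CC2CCC(OC)CC2)[C@H](c2ccc(O)c(Cl)c2)NC(=O)N1` is the next member. It differs from compound 3 by 4-methoxycyclohexyl in place of cyclohexylmethyl on a saturated chain carbon bound to a carbonyl carbon. With every measured value resting at the limit, the expected step from compound 3 to compound 4 is a step that the limit leaves unreadable from compound 3 to compound 4, none beyond the scatter and most likely another limit. Compound 4 is accordingly estimated at 20000 nM, within 8000 nM to 60000 nM.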

Compound 4, half-maximal cytotoxic concentration: > 10000 nM
Compound 4: only a limit was reported; the forecaster's own chance of this, stated with the estimate: 85%; the middle value does not contradict the limit.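

Compound 3 and compound 4 both rest on limits in this assay, so no step can be read between them for 4-methoxycyclohexyl in place of cyclohexylmethyl. The compounds shown leave open at what concentration, if any, a member of the series turns cytotoxic, because all of them sit at one limit: the limit of > 10000 nM in this assay, at which 4 of the 4 values shown sit.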